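Swapping Trifluoromethyl for Methoxy on a Phenyl Ether

A few compounds are considered here, and "the series" means these few. Any claim that something is new, unique, unknown or untested is made for them only; others in the source may bear on it.

Measured so far:
compound 1, `O=C1c2ccccc2CN1C1CCN(CC(O)COCc2ccc(C(F)(F)F)cc2)CC1`, 3000 nM
compound 2, `O=C1c2ccccc2CN1C1CCN(CC(O)COc2cccc(C(F)(F)F)c2)CC1`, 1200 nM

Both compounds were tested in an assay on isolated protein for inhibition of sodium channel protein type 1 subunit alpha (Homo sapiens), read by patch clamp; a lower number here means a stronger inhibitor, a higher number a weaker inhibitor. Compound 2 stands lowest of the two numbers, and its nearest neighbour is compound 1, whose value sits beyond the usual scatter of repeated measurements, so compound 2 is the stronger inhibitor of this pair. The two share the same core and differ only in how the aromatic ring that carries the trifluoromethyl group is attached to the chain.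

Compound 3, `COc1cccc(OCC(O)CN2CCC(N3Cc4ccccc4C3=O)CC2)c1`, has not yet been tested in this assay. It keeps the attachment of compound 2 and changes one group on the aromatic ring: methoxy in place of trifluoromethyl on an aromatic carbon. Among the measured compounds shown here, no measured pair here shows what such a swap does, so the expectation rests on the change itself and on the value of compound 2.

The expected step, a 2.1-fold higher number from compound 2 to compound 3 (0.32 log units; beyond the scatter), runs toward a higher number, that is a weaker inhibitor, and is expected to lie beyond the scatter. Compound 3 is therefore estimated to give 2500 nM, with a likely range from 900 nM to 7000 nM.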

Compound 3, half-maximal inhibitory concentration: 3000 nM
For compound 3 the middle estimate is 1.2-fold (0.08 log units) below the measured one; the measured number falls inside the stated range.
By their numbers in this assay, from the lowest: compound 2; then compounds 1 and 3 (each within the scatter of the next).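

Among the compounds shown here, compound 2 and compound 3 are the first pair here that differ in one place only, so the group on the ring can be judged on its own. In this assay, putting methoxy in place of trifluoromethyl on an aromatic carbon, meta to a large group, gives a 2.5-fold higher number from compound 2 to compound 3 (0.40 log units; beyond the scatter) and so a modestly weaker inhibitor, which shows that inhibition responds to the group at this position, although the change is not large. The swap removes a group of four heavy atoms with no hydrogen-bond acceptor and brings in one of two heavy atoms with one acceptor, but no measurement shown here explains why inhibition weakens with this swap.

From the compounds shown here alone, a single pair cannot separate the number of heavy atoms from the added acceptor, so it remains open how a methyl, a chlorine or a nitrile at this same place would compare, and how the ring would fare with only hydrogen there. Going by these compounds, it is also open whether the same swap would give a step of similar size on the ring of compound 1, where the attachment to the chain differs.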